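One aromatic group exchanged, one value still awaited

This account rests on a few compounds, and the source may have more. Where it says the series, first, only, none or still open, it means among the compounds named here.

Measured in a functional assay on SiHa cells (Homo sapiens) for antiproliferative activity, read by CCK-8 assay, with a stated time of 72 h; a lower number here means a stronger inhibitor, a higher number a weaker inhibitor:
compound 1 `COc1ccc(-c2cncnc2-c2cc(OC)c(OC)c(OC)c2)cc1F` gives 3340 nM
compound 2 `CCSc1ccc(-c2cncnc2-c2cc(OC)c(OC)c(OC)c2)cc1` gives 1030 nM
compound 3 `COc1ccc(-c2cncnc2-c2cc(OC)c(OC)c(OC)c2)nc1` gives 1750 nM

The three compounds share one core and differ only in a single aromatic group. Compound 3 at 1750 nM cannot be told apart from either of the others, as the data show a 1.9-fold lower number from compound 1 to compound 3 (0.28 log units; within the scatter) and a 1.7-fold higher number from compound 2 to compound 3 (0.23 log units; within the scatter) as steps inside the scatter.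

Compound 4 `COc1cc(-c2ncncc2-c2ccc(C(N)=O)cc2)cc(OC)c1OC` changes the same place, with 4-carbamoylphenyl in place of 5-methoxypyridin-2-yl on an aromatic carbon.

All three measured steps exchange the group at this place, so they bear directly on the change. Within the data shown here, none of the measured compounds carries a carbamoyl group, however, which leaves this estimate loosely anchored. With a 3.2-fold lower number from compound 1 to compound 2 (0.51 log units; beyond the scatter) as the largest exchange so far, no step beyond the scatter is expected in this assay and no firm direction can be assigned.

The step expected is a 1.1-fold higher number from compound 3 to compound 4 (0.06 log units; within the scatter) and it remains an estimate.

For compound 4 the estimated value is 2000 nM with an expected range from 600 nM to 7000 nM.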

Compound 4, half-maximal inhibitory concentration: > 100000 nM
Compound 4: only a limit was reported; the forecaster's own chance of this, stated with the estimate: 5%; middle value at least 50-fold (1.69 log units) away from the limit.
By their numbers in this assay, from the lowest: compounds 2, 3 and 1 (each within the scatter of the next, the first and the last beyond it). At a limit, above all of these: compound 4.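

In this assay compound 4 gives > 100000 nM, which is a limit of the assay and not a number: the limit of > 100000 nM in this assay, at which 1 of the 4 values shown sits. This shows that the place on the aromatic carbon, ortho to a large group, does not accept every aromatic group alike, as the exchange gives an at least 57-fold higher number from compound 3 to compound 4 (1.75 log units; beyond the scatter) and an at least 29-fold higher number from compound 1 to compound 4 (1.47 log units; beyond the scatter) and also an at least 97-fold higher number from compound 2 to compound 4 (1.98 log units; beyond the scatter) as large steps. The earlier compounds shown here gave no sign of this, since their largest exchange was a 3.2-fold lower number from compound 1 to compound 2 (0.51 log units; beyond the scatter) and was modest, whereas compound 2 and compound 4 differ only in carbamoyl in place of ethylsulfanyl on the same phenyl, which ties the large step to that one exchange at this place.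

What the compounds shown leave open is whether the step belongs to the carbamoyl group as a whole or to the amide hydrogen, which a nitrile, a methyl ester or a carboxylic acid on the same phenyl could help to separate. As far as these compounds go, it also remains open whether an aminomethyl group or a longer chain ending in carbamoyl would behave like compound 4 or like compound 2.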